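Carbonyl substituent changes in one series

The compounds below may be only part of what the source reports. "The series", "measured", "known", "first", "only" and "open" are said of these compounds alone.

Measured compounds, with their values in an assay on isolated protein for inhibition of Alpha glucosidase (Homo sapiens), with stated times of 5 min and 30 min; on this read-out higher numbers stand for weaker inhibition and lower numbers for stronger inhibition:
compound 1, `Cc1cs/c(=N\C(=O)c2cc3ccccc3oc2=O)n1-c1cc(Cl)c(Cl)cc1Cl`, gives 100 nM
compound 2, `COc1ccc(C(=O)/N=c2\scc(C)n2-c2cc(Cl)c(Cl)cc2Cl)cc1`, gives 100 nM
compound 3, `Cc1ccccc1C(=O)/N=c1\scc(C)n1-c1cc(Cl)c(Cl)cc1Cl`, gives 150 nM

The three numbers lie within the scatter of one another, and compound 3 is not set apart from compound 1 or compound 2. Going by the values given here, the only measured step that alters just the group on the carbonyl carbon, a 1.5-fold higher number from compound 2 to compound 3 (0.18 log units; within the scatter), stays within the scatter, so an aryl-for-aryl exchange at that position has so far left this assay essentially unmoved. Compound 1 carries a different group on the same carbon, and its value and that of compound 3 also lie within the scatter of each other.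

Compound 4, `Cc1cs/c(=N\C(=O)c2ccco2)n1-c1cc(Cl)c(Cl)cc1Cl`, differs from compound 3 by furan-2-yl in place of 2-methylphenyl on a carbonyl carbon. Among the compounds with values here, the exchange touches the same carbonyl carbon as the one measured step, but a furan-2-yl has not yet been tested in this assay, so the data give no direct precedent for a five-membered ring with a hetero atom here. For compound 4 a step of no change at the digits printed from compound 3 to compound 4 (within the scatter) is expected, that is none beyond the scatter, because a 1.5-fold higher number from compound 2 to compound 3 (0.18 log units; within the scatter) stayed within the scatter. Compound 4 is therefore estimated at 150 nM, within 60 nM to 400 nM.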

Compound 4, half-maximal inhibitory concentration: 100 nM
Compound 4: middle estimate off by 1.5-fold (0.18 log units), on the high side; the measured number falls inside the stated range.
By their numbers in this assay, from the lowest: compounds 1, 2, 4 and 3 (each within the scatter of the next).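

In this assay, going by these compounds alone, furan-2-yl puts a five-membered aromatic ring with a hetero atom on the carbonyl carbon for the first time, and neither step that can be read departs from the scatter: one is a 1.5-fold lower number from compound 3 to compound 4 (0.18 log units; within the scatter) and the other is no change at the digits printed from compound 2 to compound 4 (within the scatter) on exchanging the 4-methoxyphenyl. The position therefore accepts a smaller ring as well as the two substituted phenyl groups, and the read-out does not separate these three groups, although the entering furan-2-yl has fewer heavy atoms than 2-methylphenyl and adds a hydrogen-bond acceptor. No supporting measurement is available to explain why the read-out holds across these exchanges.

Each group shown on the carbonyl carbon is attached through an aromatic ring, so it remains open whether a longer alkyl chain, an amine or a carboxylic acid at that carbon would leave the read-out inside the scatter. The rest of the molecule is the same in all of these compounds, so it is also open whether this tolerance at the carbonyl carbon would persist with a different group in place of the trichlorinated aryl ring.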